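Ring-nitrogen substituent survey, compound 1 to compound 4

This account rests on a few compounds, and the source may have more. Where it says the series, first, only, none or still open, it means among the compounds named here.

Compound 1 `CC(C)N1CCN(Cc2csc(N)c2C(=O)c2ccc(Cl)cc2)CC1` gives 0% in an assay on CHO cells for displacement of a labelled ligand from adenosine receptor A1 (Homo sapiens), read by scintillation counting, with a stated time of 120 min, tested at 10 uM; a lower number here means less inhibition, a higher number more inhibition at the concentration tested (going by the name of the read-out). Compound 2 `Nc1scc(CN2CCN(c3ccc(Cl)cc3F)CC2)c1C(=O)c1ccc(Cl)cc1` gives 0% and compound 3 `Nc1scc(CN2CCN(c3ccncc3)CC2)c1C(=O)c1ccc(Cl)cc1` gives 1%. Compound 1 stands level with compound 2, the two together the lowest of the three numbers, and compound 3 lies within the scatter of both. The aryl replacements on the ring nitrogen gave no change at the digits printed from compound 1 to compound 2 (within the scatter) and a number 1 percentage points higher from compound 1 to compound 3 (within the scatter), and a number 1 percentage points higher from compound 2 to compound 3 (within the scatter) is flat as well. Compound 4 `Nc1scc(CN2CCN(c3cc(F)cc(F)c3)CC2)c1C(=O)c1ccc(Cl)cc1` differs from compound 1 by 3,5-difluorophenyl in place of isopropyl on an amine nitrogen in a ring. The steps from compound 1 to compound 2 and from compound 1 to compound 3 bear on this change and show nothing beyond the scatter, so the step of a number 1 percentage points higher from compound 1 to compound 4 (within the scatter) is expected to stay within the scatter. Compound 4 is therefore estimated at 1%, with a range from 0% to 10%.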

Compound 4, a percentage reported as inhibition, at one concentration (the size of the read-out at that concentration, not a potency): 0%
Compound 4: middle estimate off by 1 percentage points, on the high side, and the stated range covers the measured number.
By their numbers in this assay, from the lowest: compounds 1, 2, 4 and 3 (each within the scatter of the next).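

In this assay the 3,5-difluorophenyl group, with 8 heavy atoms where isopropyl has 3, leaves the number flat on this amine nitrogen in a ring: no change at the digits printed from compound 1 to compound 4 (within the scatter) and no change at the digits printed from compound 2 to compound 4 (within the scatter) and also a number 1 percentage points lower from compound 3 to compound 4 (within the scatter) in this survey. A third aromatic replacement therefore adds no separation among the four compounds. No measurement shown here offers an explanation for this flat result.

Open, on these data alone, is whether a carboxylic acid, a longer chain ending in an amine, or a benzyl group on this nitrogen would move the number beyond the scatter. Changes elsewhere on the shared core also remain open.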